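A methyl on the phenyl of compound 2

The source may hold more compounds than are shown below. What is called first, only, known or untested is meant among the compounds shown, and "the series" means these compounds.

Compound 1 `Cc1ccc(-c2[nH]c3ccccc3c2C2=C(Br)C(=O)C(Br)=C(Br)C2=O)cc1`: > 25 ug/mL (a limit).
Compound 2 `Cc1[nH]c2ccccc2c1C1=C(Br)C(=O)C(Br)=C(c2c(-c3ccccc3)[nH]c3ccccc23)C1=O`: 3.02 ug/mL.

In a functional assay on MCF7 cells (Homo sapiens) for antiproliferative activity, read by CCK-8 assay, with a stated time of 48 h (on this read-out higher numbers stand for weaker inhibition and lower numbers for stronger inhibition), compound 1 gives only a limit, > 25 ug/mL. Going by the values given here, compound 2 gives 3.02 ug/mL, the one number in the set. The other entry, that of compound 1, is a limit (the limit of > 25 ug/mL in this assay, at which 1 of the 2 values shown sits). Compound 3 `Cc1ccc(-c2[nH]c3ccccc3c2C2=C(Br)C(=O)C(Br)=C(c3c(C)[nH]c4ccccc34)C2=O)cc1` differs from compound 2 by methyl in place of hydrogen on an aromatic carbon, para to a large group. Among the compounds with values here, no step between measured compounds exists here, so the change is expected to move the value by no more than the scatter, in no set direction. Compound 3 is expected to give 3.5 ug/mL, between 1.2 ug/mL and 10 ug/mL, a step of a 1.2-fold higher number from compound 2 to compound 3 (0.06 log units; within the scatter).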

Compound 3, half-maximal inhibitory concentration: 6.85 ug/mL
Compound 3: the middle estimate sits 2.0-fold (0.29 log units) below what was measured; the measured number falls inside the stated range.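

Phenyl to 4-methylphenyl is not silent in this assay: the change gives a 2.3-fold higher number from compound 2 to compound 3 (0.36 log units; beyond the scatter), so this carbon, para to a large group, responds to a single added methyl. Placing 2-methyl-1H-indol-3-yl in place of bromo on a double-bonded ring carbon gives an at least 3.6-fold lower number from compound 1 to compound 3 (0.56 log units; beyond the scatter), so that step holds with the 4-methylphenyl group in place. The entry for compound 1 is a limit, so this step has no fixed size: the limit of > 25 ug/mL in this assay, at which 1 of the 3 values shown sits.

Open, as far as these compounds go, is how a methoxy group, a chlorine or an amine on this same carbon would read, and whether a longer chain would push the number further in the same direction.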